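The source may report more compounds than this note shows. Statements on the series, on what has been measured and on what is new or still open speak of the compounds shown alone.

Compound 3 `COC(=O)c1nc(Br)c2cccnc2c1N[C@H]1CC[C@H](N)CC1` carries a methoxycarbonyl group, and in a functional assay on SK-BR-3 cells (Homo sapiens) for cytotoxicity, read by MTT assay, with a stated time of 72 h (on this read-out higher numbers stand for weaker inhibition and lower numbers for stronger inhibition), the result for compound 3 is "not determined" (no result reported) with no single number to start from. Compound 4 `N[C@H]1CC[C@H](Nc2c(C(=O)NC3CCCCC3)nc(Br)c3cccnc23)CC1` has cyclohexylamino in place of methoxy on a carbonyl carbon, so methoxycarbonyl becomes cyclohexylcarbamoyl.

With no number for compound 3, the size and direction of this step cannot be read from compound 3 itself. The nearest evidence comes from two compounds that also have an amide on that carbonyl carbon. In this assay compound 1 `N[C@H]1CC[C@H](Nc2c(C(=O)NCc3ccc(F)cc3)nc(Br)c3cccnc23)CC1` gives 2000 nM while compound 2 `C[C@H](NC(=O)c1nc(Br)c2cccnc2c1N[C@H]1CC[C@H](N)CC1)c1ccc(F)cc1` gives 9000 nM in the same test.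

Among the compounds with values here, the only measured step, a 4.5-fold higher number from compound 1 to compound 2 (0.65 log units; beyond the scatter) (methyl in place of hydrogen on a saturated chain carbon), is modest and beyond the scatter. It shows how far one small change moved the number within this pair of amides, but it does not involve methoxy or cyclohexylamino. Within the data shown here, no measured compound carries a cyclohexyl group, so the expectation is only that compound 4 will fall in the same general region as compound 1 and compound 2, with a wide margin.

The estimated value for compound 4 is 4000 nM in an expected range from 1000 nM to 15000 nM on this read-out.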

Compound 4, half-maximal inhibitory concentration: 4200 nM
Beside the measured number, compound 4's estimate is 1.1-fold (0.02 log units) below it; the measured number falls inside the stated range.
By their numbers in this assay, from the lowest: compound 1; then compound 4; then compound 2.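

Until now, both amides with a number in this assay carried a fluorophenyl group on the amide-type nitrogen, so it was unclear whether a number in this region needed that aromatic ring. Compound 4 has cyclohexyl there instead, a six-membered non-aromatic ring of carbon only, and its number falls between the other two: replacing 1-(4-fluorophenyl)ethyl gives a 2.1-fold lower number from compound 2 to compound 4 (0.33 log units; beyond the scatter) and replacing 4-fluorobenzyl gives a 2.1-fold higher number from compound 1 to compound 4 (0.32 log units; beyond the scatter) in the opposite direction. Both steps are modest though beyond the usual scatter, so among these three amides a number in this region does not depend on an aromatic ring or a fluorine on that nitrogen.

Compound 3 has no reported result and its step to compound 4 cannot be read, which leaves open how an amide on this carbonyl carbon compares with the methoxycarbonyl group, and how a carboxylic acid or a small amide such as a methylamide would compare. No measurement shown here explains the size or direction of these steps.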